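A Pyridinyl Ethyl Group Against a Limit-Bound Pair

The source may hold more compounds than are shown below. What is called first, only, known or untested is meant among the compounds shown, and "the series" means these compounds.

Compound 1 `CC(C)(C)Sc1c(CC(C)(C)C(=O)O)n(Cc2ccc(Cl)cc2)c2ccc(OCc3ccc4cc(F)c(F)cc4n3)cc12` was tested in a functional assay (blood) for inhibition, with Homo sapiens as the target; on this read-out lower numbers stand for stronger inhibition and higher numbers for weaker inhibition. In this assay compound 1 reaches only > 3000 nM, which is a limit of the assay and not a number. Its close relative compound 2 `CC(C)(C)Sc1c(CC(C)(C)C(=O)O)n(Cc2ccc(Cl)cc2)c2ccc(OCc3ccncc3)cc12` likewise gives > 3000 nM in this assay, again a limit rather than a number. For the measured compounds named here, the only step measured so far, a step that the two limits leave unreadable from compound 1 to compound 2, therefore cannot be read in size or direction, because both values sit at the limit of > 3000 nM in this assay, at which 2 of the 2 values shown sit. Compound 3 `C[C@H](COc1ccc2c(c1)c(SC(C)(C)C)c(CC(C)(C)C(=O)O)n2Cc1ccc(Cl)cc1)c1ccccn1` differs from compound 1 in one place: a group of 8 heavy atoms (7 carbon, 1 nitrogen; one six-membered aromatic ring with 1 hetero atom) in place of a group of 12 heavy atoms (9 carbon, 1 nitrogen, 2 fluorine; one six-membered aromatic ring of carbon only, one six-membered aromatic ring with 1 hetero atom), on a saturated chain carbon bound to an oxygen on an aromatic ring. Going by the values given here, no measured step bears on this exact change, and the single known step runs between two limits, so it offers no size or direction to carry over. All that the numbers show is that compound 1 and compound 2 both remain beyond the reach of this assay, and with a related change compound 3 is most likely to behave the same way. Compound 3 is therefore expected near 3500 nM, between 600 nM and 15000 nM, which means an expected step that the limit leaves unreadable from compound 1 to compound 3 of essentially none beyond the scatter.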

Compound 3, half-maximal inhibitory concentration: 470 nM
Compound 3: middle estimate off by 7.4-fold (0.87 log units), on the high side; the measured number lies below the stated range.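

Until now this place, a saturated chain carbon bound to an oxygen on an aromatic ring, had offered only limits, and the step between compound 1 and compound 2 cannot be read, because both values are limits: the limit of > 3000 nM in this assay, at which 2 of the 3 values shown sit.

For the compounds shown here, compound 3 gives the first readable number of the set in this assay, as 1-(pyridin-2-yl)ethyl at this place gives an at least 6.3-fold lower number from compound 1 to compound 3 (0.80 log units; beyond the scatter) and, set against the pyridin-4-yl group, gives an at least 6.3-fold lower number from compound 2 to compound 3 (0.80 log units; beyond the scatter). The group at this place can therefore move the read-out beyond the scatter, and each step gives only the smallest size that fits, with the true size possibly larger.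

The compounds shown leave open which feature of the new group matters, since it differs from pyridin-4-yl both in how the ring is attached and in its branched chain with one defined stereocentre. On these data alone, a 1-(pyridin-4-yl)ethyl or 1-phenylethyl group, or the mirror-image form of compound 3, would help separate these features, and how far the gain extends beyond this one compound also remains open.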